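Adding a Fluoro Group to the Phenyl Ring of Compound 2

The source may hold more compounds than are shown below. What is called first, only, known or untested is meant among the compounds shown, and "the series" means these compounds.

Compound 1, `Cc1nc(-c2ccccc2)c(C(=O)N2CCN(c3cccc(C(N)=O)c3)CC2)o1`: 71 nM
Compound 2, `Cc1ccc(C)c(N2CCN(C(=O)c3oc(C)nc3-c3ccccc3)CC2)c1`: 31.3 nM

Going by the values given here, in a functional assay on HL-60 cells (Homo sapiens) for inhibition, read by MTT assay, with a stated time of 72 h (a higher number here means a weaker inhibitor, a lower number a stronger inhibitor), compound 2 gives 31.3 nM, the lowest of the two numbers measured so far. Among the compounds with values here, compound 1 gives 71 nM, and the single measured step is a 2.3-fold lower number from compound 1 to compound 2 (0.36 log units; beyond the scatter). Compound 3, `Cc1ccc(C)c(N2CCN(C(=O)c3oc(C)nc3-c3cccc(F)c3)CC2)c1`, has not yet been measured. It differs from compound 2 in one place: fluoro in place of hydrogen on an aromatic carbon. Seen one bond further out, the change reads phenyl to 3-fluorophenyl. Within the data shown here, the one measured step concerns a different part of the molecule, the group on the amine nitrogen in a ring, so it gives no guide to what a fluoro on this aromatic ring does. With nothing to point either way, the expected step is a 1.0-fold lower number from compound 2 to compound 3 (0.02 log units; within the scatter), which is no change beyond the scatter. Compound 3 is therefore estimated at 30 nM, with a range from 12 nM to 80 nM.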

Compound 3, half-maximal inhibitory concentration: 204 nM
The estimate for compound 3 lay 6.8-fold (0.83 log units) below the measured number; the measured number lies above the stated range.
By their numbers in this assay, from the lowest: compound 2; then compound 1; then compound 3.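

In this assay, the phenyl ring turns out to be sensitive to even a very small change: putting a single fluoro on an aromatic carbon, meta to a large group, gives a 6.5-fold higher number from compound 2 to compound 3 (0.81 log units; beyond the scatter). This one-atom change moves the number further than the exchange of a whole group on the ring nitrogen, which gave a 2.3-fold lower number from compound 1 to compound 2 (0.36 log units; beyond the scatter), so the phenyl ring cannot be treated as a place where changes pass without effect. Nothing measured here explains why the fluoro raises the number.

The compounds shown leave open whether this rise is particular to fluoro at this place, or whether a chloro or methoxy group there, or a 4-fluorophenyl ring, would raise the number as well. They also leave open whether the same fluoro would have a similar effect alongside the 3-carbamoylphenyl group of compound 1.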